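A few compounds are considered here, and "the series" means these few. Any claim that something is new, unique, unknown or untested is made for them only; others in the source may bear on it.

Two compounds of the series have numbers in a functional assay on the whole organism for inhibition, with Mythimna separata as the target, with a stated time of 5 days; on this read-out higher numbers stand for an effect only at larger amounts of compound and lower numbers for an effect already at smaller amounts. Compound 1 `CC(C)(C)n1ncc(OCc2nnc(-c3c(F)c(F)c(F)c(F)c3F)o2)c(Cl)c1=O` gives 271000 nM in this assay. Compound 2 `CC(C)(C)n1ncc(OCc2nnc(-c3cccc(F)c3)o2)c(Cl)c1=O` gives 7100 nM in this assay, the lower of the two numbers, and the gap between compound 2 and compound 1 lies beyond the scatter. Among the compounds with values here, no measured pair differs in a single place, so the size of one isolated change is not yet known from the series itself.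

Compound 3 `CCc1ccc(-c2nnc(COc3cnn(C(C)(C)C)c(=O)c3Cl)o2)cc1` is the next member to be measured. It differs from compound 2 in one place: 4-ethylphenyl in place of 3-fluorophenyl on an aromatic carbon. The comparison of compound 1 with compound 2 shows that exchanging the aryl at this place can shift the number far, but it gives no direction for an alkyl-bearing phenyl. The expected step in this assay is therefore small, a 1.4-fold lower number from compound 2 to compound 3 (0.15 log units; within the scatter), without a confident direction. Compound 3 is expected to give about 5000 nM in this assay, between 1200 nM and 20000 nM.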

Compound 3, half-maximal effective concentration: 14500 nM
For compound 3 the middle estimate is 2.9-fold (0.46 log units) below the measured one, within the range that was stated.
By their numbers in this assay, from the lowest: compound 2; then compound 3; then compound 1.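

In this assay, the position on the aromatic carbon of the five-membered ring now has its first isolated change: 4-ethylphenyl in place of 3-fluorophenyl gives a 2.0-fold higher number from compound 2 to compound 3 (0.31 log units; beyond the scatter), a modest step beyond the scatter. This single exchange therefore has a direction, and for this pair the number rises with the ethyl-bearing ring rather than falls. No available evidence bears on the origin of this step.

The exchange removes the fluorine and introduces the ethyl group at once, so the part played by each remains unresolved. A plain phenyl would separate the two, while a phenyl bearing an amine, a carboxylic acid or a chain longer than ethyl would show how far this position extends beyond the two aryl groups compared here.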